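The source may hold more compounds than are shown below. What is called first, only, known or untested is meant among the compounds shown, and "the series" means these compounds.

Compound 1 `COc1ccccc1N1CCN(CC2=NS(=O)(=O)c3ccc(C)cc3N2)CC1` and compound 2 `COc1ccccc1N1CCN(CC2=NS(=O)(=O)c3ccc(Cl)cc3N2)CC1` share one core and differ only in one spot: chloro in place of methyl on an aromatic carbon. In a functional assay on thoracic aorta for antagonist activity at Alpha-1D adrenergic receptor (Rattus norvegicus) (on this read-out higher numbers stand for higher potency (the scale is a negative logarithm) and lower numbers for lower potency), compound 1 gives 5.5, while compound 2 gives 7.75, so this change produced a number 2.25 log units higher from compound 1 to compound 2 (beyond the scatter). Compound 3 `COc1ccccc1N1CCN(CC2Nc3cc(C)ccc3S(=O)(=O)N2)CC1` is built on another core; how the two cores differ is not broken down here. In this assay compound 3 gives 5.98. Compound 4 `COc1ccccc1N1CCN(CC2Nc3cc(Cl)ccc3S(=O)(=O)N2)CC1` has not been measured yet and differs from compound 3 by chloro in place of methyl on an aromatic carbon, the same change at the same kind of place as between compound 1 and compound 2. Because that earlier change gave a number 2.25 log units higher from compound 1 to compound 2 (beyond the scatter), a step of similar size is expected for compound 4, namely a number 1.72 log units higher from compound 3 to compound 4 (beyond the scatter). Compound 4 is therefore estimated at 7.7, most likely between 6.9 and 8.4.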

Compound 4, negative logarithm of the antagonist equilibrium constant: 5
The estimate for compound 4 lay 2.70 log units above the measured number; the measured number lies below the stated range.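

Putting chloro in place of methyl on the core of compound 3 gave a number 0.98 log units lower from compound 3 to compound 4 (beyond the scatter), so in this assay the step seen on the core of compound 1 did not carry over, and the two steps differ: the same change on two cores in this assay, a number 2.25 log units higher (beyond the scatter) from compound 1 to compound 2 and a number 0.98 log units lower (beyond the scatter) from compound 3 to compound 4, 3.23 log units apart, beyond the scatter of two such steps. In this series, then, the effect of this swap depends on the core that carries it, and a step measured on one core is a poor guide to the same step on the other. This does not show why the two cores part ways, and one pair per core sets no rule for any further core.

The compounds shown carry only methyl or chloro at this aromatic carbon. As far as these compounds go, how a fluoro, a methoxy or an amine there would behave on each core stays open.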